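The source may report more compounds than this note shows. Statements on the series, on what has been measured and on what is new or still open speak of the compounds shown alone.

Measured so far in a functional assay (muscle tissue) with Cavia porcellus as the target; a higher number here means that more compound is needed for the effect, a lower number that less compound is needed:
Compound 1, `COC(=O)C1=C(C)N=C(C)/C(=C(\O)OC)C1c1cccc(OC)c1`: 191 nM
Compound 2, `COC(=O)C1=C(C)N=C(C)/C(=C(\O)OC)C1c1ccccc1N`: 39800 nM
Compound 3, `COC(=O)C1=C(C)N=C(C)/C(=C(\O)OC)C1c1cccc(O)c1`: 1000 nM

Compound 3 stands second highest of the three numbers; its nearest neighbour is compound 1, at a lower number, by a 5.2-fold higher number from compound 1 to compound 3 (0.72 log units; beyond the scatter), while compound 2 lies far higher, by a 40-fold lower number from compound 2 to compound 3 (1.60 log units; beyond the scatter). The unmeasured compound 4, `COC(=O)C1=C(C)N=C(C)/C(=C(\O)OC)C1c1cccc(N(C)C)c1`, differs from compound 3 by dimethylamino in place of hydroxy on an aromatic carbon. Among the compounds with values here, the step that bears on it most directly is the one from compound 1 to compound 3, a 5.2-fold higher number from compound 1 to compound 3 (0.72 log units; beyond the scatter), where a hydrogen replaced the methyl on the aromatic oxygen; the new group, like methoxy in compound 1, keeps one acceptor and has no donor. The steps touching compound 2, a 210-fold higher number from compound 1 to compound 2 (2.32 log units; beyond the scatter), concern a different group at a different place and are not taken as a guide. A modest step toward lower numbers is therefore expected, a 3.3-fold lower number from compound 3 to compound 4 (0.52 log units; beyond the scatter), back toward the level of compound 1. Compound 4 is estimated at 300 nM, within 80 nM to 1200 nM.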

Compound 4, half-maximal effective concentration: 891 nM
Estimate against measurement, compound 4: 3.0-fold (0.47 log units) below, within the range that was stated.
By their numbers in this assay, from the lowest: compound 1; then compounds 4 and 3 (each within the scatter of the next); then compound 2.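

In this assay, dimethylamino in place of hydroxy on this aromatic carbon leaves the number within the scatter (a 1.1-fold lower number from compound 3 to compound 4 (0.05 log units; within the scatter)), so removing the hydrogen-bond donor does not on its own bring the number back to that of compound 1. Dimethylamino in place of methoxy shows that the two donor-free groups are not interchangeable here (a 4.7-fold higher number from compound 1 to compound 4 (0.67 log units; beyond the scatter)), which leaves methoxy as the only group at this place, among those shown, that gives the low number. Nothing measured here bears on the reason for this difference.

Going by these compounds, it remains open whether ethoxy or a longer ether chain would keep the number of compound 1, or whether it is specific to methoxy. On these data alone, it is equally open whether a plain amino group or methylamino at this place would track with dimethylamino.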